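Adding Bromine to a Weakly Active Kinase Inhibitor

This account rests on a few compounds, and the source may have more. Where it says the series, first, only, none or still open, it means among the compounds named here.

Compound 3 `COc1ccccc1Cn1c(-c2cccnc2N)nc2cccnc21` sits at the weak end of what has been measured so far. In an in vitro assay on Sf9 cells for inhibition of RAC-alpha serine/threonine-protein kinase (Homo sapiens), read by AlphaScreen, with a stated time of 20 min (a lower number here means a stronger inhibitor, a higher number a weaker inhibitor), compound 3 gives 58000 nM, the highest of the two numbers reported. The nearest number belongs to compound 1 `Nc1ncccc1-c1nc2cc(C3CCCC3)cnc2n1-c1ccc(CNC(=O)c2ccccc2)cc1`, which in this assay gives 110 nM; the gap between compound 3 and compound 1 lies far beyond the usual scatter. Compound 2 `CC(C)(C)c1ccc(-n2c(-c3cccnc3N)nc3cc(Br)cnc32)cc1` gives in this assay only a limit, > 300000 nM, and not a number; that is the limit of > 300000 nM in this assay, at which 1 of the 3 values shown sits.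

Compound 4 `COc1ccccc1Cn1c(-c2cccnc2N)nc2cc(Br)cnc21` is compound 3 with a single change: bromo in place of hydrogen on an aromatic carbon. Going by the values given here, no two measured compounds differ by this change alone, so its effect cannot be read directly. Compound 2 carries a bromo at the same place but also a different group on the ring nitrogen, and compound 1 carries a cyclopentyl there together with yet another group, so neither isolates the bromo.

On that basis the step is expected to be small, within or just beyond the scatter, with a slight lean towards a lower number; the expected step from compound 3 to compound 4 is a 1.9-fold lower number from compound 3 to compound 4 (0.29 log units; within the scatter). Compound 4 is therefore estimated to give 30000 nM in this assay, with a plausible range from 5000 nM to 150000 nM.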

Compound 4, half-maximal inhibitory concentration: > 300000 nM
Compound 4: only a limit was reported; the forecaster's own chance of this, stated with the estimate: 10%; middle value at least 10-fold (1.00 log units) from the limit.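

Going by these compounds alone, on the core of compound 3, this one change at the aromatic carbon two atoms from the ring nitrogen moves the result the wrong way in this assay: bromo in place of hydrogen gives an at least 5.1-fold higher number from compound 3 to compound 4 (0.71 log units; beyond the scatter), so here the added bromine costs activity and does not buy any, a direct reading that no earlier pair could offer. On these data alone, compound 4 reports only a limit of the assay, > 300000 nM, and not a number, so the step marks the smallest loss the data allow and its true size stays unknown. The weak end of this small set is now crowded, and any further loss at this position could not be seen as a number: the limit of > 300000 nM in this assay, at which 2 of the 4 values shown sit.

What the compounds shown leave open is whether the loss belongs to bromo alone or to any group at this place, as a fluoro, a chloro, a methyl or an amine on the same core could tell. Compound 1 carries a cyclopentyl at this place but also differs elsewhere, and it cannot show whether the group on the ring nitrogen changes how this position responds.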